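Methoxy for Fluoro in a Tolerated Cytotoxicity Series

The source may report more compounds than this note shows. Statements on the series, on what has been measured and on what is new or still open speak of the compounds shown alone.

Compound 1, `CNC(=O)c1c(NO)cc(-c2ccc(OC)cc2)oc1=O`, and compound 2, `O=C(NCc1ccccc1)c1c(NO)cc(-c2ccc(F)cc2)oc1=O`, share one core and differ both in the amide substituent and in the group carried on the aryl ring. In an ADME assay on Huh-7 cells (Homo sapiens) for cytotoxicity, read by a luciferase reporter and WST assay, with a stated time of 3 days (a higher number here means that more compound is tolerated, a lower number that less compound is tolerated), compound 1 gives > 20000 nM, which is a limit of the assay and not a number. In this assay compound 2 likewise gives > 20000 nM, again a limit rather than a measured value. Compound 2 therefore stands exactly where every value shown stands, namely at the limit of > 20000 nM in this assay, at which 2 of the 2 values shown sit.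

Compound 3, `COc1ccc(-c2cc(NO)c(C(=O)NCc3ccccc3)c(=O)o2)cc1`, differs from compound 2 by methoxy in place of fluoro on an aromatic carbon; cut one bond further out, 4-fluorophenyl becomes 4-methoxyphenyl. Among the measured compounds shown here, no step between measured compounds is available, and because the limit of > 20000 nM in this assay, at which 2 of the 2 values shown sit, places both measured values at the same limit, compound 3 is expected to show no step beyond the scatter in this assay. The estimated step that the limit leaves unreadable from compound 2 to compound 3 is accordingly expected to be essentially flat. The estimate for compound 3 is 25000 nM, expected to fall between 10000 nM and 60000 nM, most probably reported again only as a limit.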

Compound 3, half-maximal cytotoxic concentration: > 20000 nM
Compound 3 gave a limit, no number; the forecaster's own chance of this, stated with the estimate: 85%; the middle value does not contradict the limit.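

Among the compounds shown here, no step to compound 3 from compound 1 or compound 2 can be read, because all three compounds rest at a single limit of the assay and not at numbers: the limit of > 20000 nM in this assay, at which 3 of the 3 values shown sit. The compounds shown leave open how much compound each of the three tolerates past that limit, and whether any change at the amide or on the aryl ring would bring cytotoxicity into measurable range.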